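Cytotoxicity notes: fluoro to trifluoromethyl on two cores

This account rests on a few compounds, and the source may have more. Where it says the series, first, only, none or still open, it means among the compounds named here.

Measured compounds:
compound 1, `CC(=O)Nc1ccc(O)c(C(=O)/C=C/c2cccc(F)c2)c1`, 30100 nM
compound 2, `CC(=O)Nc1ccc(O)c(C(=O)/C=C/c2cccc(C(F)(F)F)c2)c1`, 32100 nM
compound 3, `CC(=O)Nc1ccc2oc(-c3cccc(F)c3)cc(=O)c2c1`, 240000 nM

All three were run in an ADME assay on MT4 cells (Homo sapiens) for cytotoxicity, read by MTT assay, with a stated time of 4 days; on this read-out lower numbers stand for higher toxicity in this test and higher numbers for lower toxicity in this test. Compound 1 and compound 2 share one core and differ only in the change (trifluoromethyl in place of fluoro on an aromatic carbon); the step of a 1.1-fold higher number from compound 1 to compound 2 (0.03 log units; within the scatter) is within the usual scatter, so the two values are treated as alike. Compound 3 sits on a different core and gives the highest number of the three; the difference between the two cores is not broken down here.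

Compound 4, `CC(=O)Nc1ccc2oc(-c3cccc(C(F)(F)F)c3)cc(=O)c2c1`, is not yet measured. It differs from compound 3 by trifluoromethyl in place of fluoro on an aromatic carbon, which is the same change as that from compound 1 to compound 2, made on the same kind of place. On the first core this change moved the read-out by a step within the scatter. Among the compounds with values here, with only that one precedent, the expectation for compound 4 in this assay is a step of the same small size, a 1.0-fold higher number from compound 3 to compound 4 (0.02 log units; within the scatter), because the measured pair gave a 1.1-fold higher number from compound 1 to compound 2 (0.03 log units; within the scatter). Whether the second core answers the change in the same way is not shown by any measured pair, so the range is kept wide. Compound 4 is therefore expected at about 250000 nM, estimated between 120000 nM and 500000 nM, close to the value of compound 3.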

Compound 4, half-maximal cytotoxic concentration: 10000 nM
Beside the measured number, compound 4's estimate is 25-fold (1.40 log units) above it; measured number below the stated range.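

In this assay, trifluoromethyl in place of fluoro on an aromatic carbon gives a 24-fold lower number from compound 3 to compound 4 (1.38 log units; beyond the scatter), a large step towards higher toxicity in this test on the second core. The size of the step does not carry over from one core to the other, and the two pairs clearly disagree: the same change on two cores in this assay, a 1.1-fold higher number (0.03 log units; within the scatter) from compound 1 to compound 2 and a 24-fold lower number (1.38 log units; beyond the scatter) from compound 3 to compound 4, 26-fold (1.41 log units) apart, beyond the scatter of two such steps. This shows that, within these two pairs, the outcome of the change depends on the core it is made on, so a step measured on one core is a poor guide to the other; it does not show which feature of the cores accounts for the gap, nor how the change would behave on any further core.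

Still open, as far as these compounds go, is whether the large step belongs to trifluoromethyl alone or would also appear with a chlorine, a methoxy group, a nitrile or an amine on the same aromatic carbon of both cores. Also open, from the compounds shown here alone, is how a hydrogen at that place would compare with fluoro on each core, which would give both pairs a common point of reference.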